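Sulfamoyl for Nitro on an Aziridine Urea Series

This account rests on a few compounds, and the source may have more. Where it says the series, first, only, none or still open, it means among the compounds named here.

Measured compounds:
compound 1, `N#CC1CN1C(=O)Nc1ccc(Cl)c(Cl)c1`, 4600 nM;
compound 2, `N#CC1CN1C(=O)Nc1ccc([N+](=O)[O-])cc1`, 3000 nM;
compound 3, `CCNC(=O)N1CC1C#N`, 29000 nM.

In a functional assay on MCF7 cells (Homo sapiens) for inhibition (on this read-out higher numbers stand for weaker inhibition and lower numbers for stronger inhibition), compound 2 gives the lowest number of the three, yet compound 1 sits within the usual scatter of it, so the two cannot be ranked; compound 3 lies clearly beyond the scatter, at a higher number. Compound 4, `N#CC1CN1C(=O)Nc1ccc(S(N)(=O)=O)cc1`, has not been measured. It differs from compound 2 by sulfamoyl in place of nitro on an aromatic carbon. Among the compounds with values here, no measured pair shows this change, so its size is not known. The step from compound 2 to compound 4 in this assay is expected to be a 1.7-fold higher number from compound 2 to compound 4 (0.22 log units; within the scatter), small and toward a higher number, possibly no larger than the scatter. Compound 4 is therefore estimated at 5000 nM, in a range from 1500 nM to 20000 nM.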

Compound 4, half-maximal inhibitory concentration: > 15000 nM
Compound 4 ended at the assay's limit; the forecaster's own chance of this, stated with the estimate: 5%; middle value at least 3.0-fold (0.47 log units) from the limit.
By their numbers in this assay, from the lowest: compounds 2 and 1 (each within the scatter of the next); then compound 3.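

In this assay, within the data shown here, the change from nitro to sulfamoyl on this aromatic carbon is not silent, as the step is an at least 5.0-fold higher number from compound 2 to compound 4 (0.69 log units; beyond the scatter) and the earlier compounds held no reading of this change. Compound 4 stands at a limit of the assay, so the step gives only a lower bound on the size of the change: the limit of > 15000 nM in this assay, at which 1 of the 4 values shown sits.

As far as these compounds go, how far compound 4 lies past that limit remains unknown. Also open, from the compounds shown here alone, is whether an amine, a carboxylic acid or a methylsulfonyl group on this aromatic carbon would stay near compound 2 or move as sulfamoyl does.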